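Replacing the pyrazole on the amide nitrogen with an isoxazole

The source may report more compounds than this note shows. Statements on the series, on what has been measured and on what is new or still open speak of the compounds shown alone.

Measured compounds:
compound 1, `Cc1ccc(OCC(=O)N(Cc2cccs2)c2ccncc2)cc1`, 52 nM
compound 2, `C=CCN(Cc1cccs1)C(=O)COc1ccc(C)cc1`, 20 nM
compound 3, `Cc1ccc(OCC(=O)N(Cc2cccs2)c2c(C)n[nH]c2C)cc1`, 0.3 nM

In an assay on HEK293 cells for agonist activity at transient receptor potential cation channel subfamily M member 8 (Homo sapiens), read by fluorescence and calcium flux, with a stated time of 15 min (on this read-out lower numbers stand for an effect already at smaller amounts and higher numbers for an effect only at larger amounts of compound), compound 3 gives the lowest number of the three measured compounds. Its nearest neighbour is compound 2, with a 67-fold lower number from compound 2 to compound 3 (1.82 log units; beyond the scatter), and the furthest is compound 1, with a 170-fold lower number from compound 1 to compound 3 (2.24 log units; beyond the scatter). Both steps onto compound 3 are large, whereas a 2.6-fold lower number from compound 1 to compound 2 (0.41 log units; beyond the scatter) is modest. Compound 4, `Cc1ccc(OCC(=O)N(Cc2cccs2)c2ccon2)cc1`, carries 1,2-oxazol-3-yl in place of 3,5-dimethyl-1H-pyrazol-4-yl on an amide-type nitrogen. Among the compounds with values here, no measured pair shows this exact exchange. What the data do show is that the 3,5-dimethyl-1H-pyrazol-4-yl on this nitrogen stands far apart from both pyridin-4-yl and allyl, so the account expects compound 4, which keeps a five-membered aromatic ring with 2 hetero atoms but loses the 1 hydrogen-bond donor, to land between compound 3 and compound 1. The expected step is a 33-fold higher number from compound 3 to compound 4 (1.52 log units; beyond the scatter), an increase well beyond the scatter. Compound 4 is therefore estimated at 10 nM in this assay, with a range from 1.5 nM to 80 nM.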

Compound 4, half-maximal effective concentration: 2 nM
For compound 4 the middle estimate is 5.0-fold (0.70 log units) above the measured one; the range from low to high includes it.
By their numbers in this assay, from the lowest: compound 3; then compound 4; then compound 2; then compound 1.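

In this assay, the 1,2-oxazol-3-yl on the amide-type nitrogen has 0 hydrogen-bond donors, yet the exchange is only a modest step, a 6.7-fold higher number from compound 3 to compound 4 (0.82 log units; beyond the scatter), and compound 3 keeps the lowest number. The low numbers at this position are therefore not confined to the 3,5-dimethyl-1H-pyrazol-4-yl: the new ring also stands clear of the allyl, a 10-fold lower number from compound 2 to compound 4 (1.00 log units; beyond the scatter), and of the pyridin-4-yl, a 26-fold lower number from compound 1 to compound 4 (1.41 log units; beyond the scatter). No measurement shown here bears on what lies behind these steps.

The exchange alters the ring atoms, the hydrogen-bond donor and the methyl groups together, so the compounds shown cannot apportion the step among these differences. From the compounds shown here alone, it remains open where an isoxazole that carries methyl groups, or a pyrazole without them, would fall on this nitrogen.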